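Replacing the carbamoyl group: a chloro analogue in the rat assay

The source may report more compounds than this note shows. Statements on the series, on what has been measured and on what is new or still open speak of the compounds shown alone.

Compound 1 `Cc1cn2cccc(OCc3ccccc3)c2n1`: 62%
Compound 2 `Cc1nc2c(OCc3ccccc3)cccn2c1C(N)=O`: 42%
Compound 3 `Cc1nc2c(OCc3ccccc3)cccn2c1C[S+](C)[O-]`: 0%

Of the compounds shown here, three sharing one core have been tested in a functional assay on the whole organism with Rattus norvegicus as the target, with a stated time of 4 h, at a dose of 40 mg/kg by the intraperitoneal route; a higher number here means more inhibition at the dose given (going by the name of the read-out), a lower number less inhibition. Compound 1 gives 62%, compound 2 gives 42% and compound 3 gives 0%. Compound 2 thus stands second highest of the three, separated from compound 1 by a number 20 percentage points lower from compound 1 to compound 2 (beyond the scatter) and from compound 3 by a number 42 percentage points lower from compound 2 to compound 3 (beyond the scatter), both beyond the scatter.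

Compound 4 `Cc1nc2c(OCc3ccccc3)cccn2c1Cl` has not yet been measured. It differs from compound 2 in one place: chloro in place of carbamoyl on an aromatic carbon. Within the data shown here, the steps that bear on this change all alter the group at the same position of the core. Among the measured compounds shown here, the step of a number 20 percentage points lower from compound 1 to compound 2 (beyond the scatter) was modest, the step of a number 42 percentage points lower from compound 2 to compound 3 (beyond the scatter) large, and the step of a number 62 percentage points lower from compound 1 to compound 3 (beyond the scatter) large, so larger groups at this position have gone with lower inhibition, with no compound going against that among the three. Chloro is the smallest of the groups placed there other than hydrogen, so a step upward from compound 2 is expected, of modest size and beyond the scatter, in this assay. The step from compound 2 to compound 4 is therefore estimated to be a number 10 percentage points higher from compound 2 to compound 4 (within the scatter). Compound 4 is expected to give about 52%, within a range of 25% to 75%.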

Compound 4, a percentage reported as inhibition, in the whole organism at one dose (the size of the read-out at that dose, not a potency): 93%
Compound 4: the middle estimate sits 41 percentage points below what was measured; the whole stated range lies below it.
By their numbers in this assay, from the lowest: compound 3; then compound 2; then compound 1; then compound 4.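

In this assay, the group on this aromatic carbon next to the ring nitrogen can raise the number as well as lower it: a number 31 percentage points higher from compound 1 to compound 4 (beyond the scatter) is a rise over hydrogen, whereas carbamoyl and the group of 4 heavy atoms both lowered it. The count of heavy atoms therefore does not order these compounds, and compound 4 goes against that order, since chloro stands above hydrogen although it is the larger of the two. The replacements of the larger groups by chloro, a number 51 percentage points higher from compound 2 to compound 4 (beyond the scatter) and a number 93 percentage points higher from compound 3 to compound 4 (beyond the scatter), point the same way, but nothing available explains why chloro behaves differently.

On these data alone, it remains open whether this rise is particular to chloro or would extend to a bromo or methyl group at this carbon. As far as these compounds go, how an amine or a carboxylic acid would fare here also remains unknown.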